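This account rests on a few compounds, and the source may have more. Where it says the series, first, only, none or still open, it means among the compounds named here.

Of the compounds shown here, three that share one core have been measured in an ADME assay, in phosphate buffer, at 28 degrees C, at pH 7.0; a lower number here means that the compound disappears faster, a higher number that the compound lasts longer. Compound 1 `CC(C)(C)C1=C(C(=O)O)N2C(=O)[C@H](CO)[C@H]2O1` gives 5 h, the lowest of the three numbers. Compound 2 `COC(=O)[C@@H](O)[C@H]1C(=O)N2C(C(=O)O)=C(C(C)(C)C)O[C@H]12` gives 6.2 h, and compound 3 `CC(C)(C)C1=C(C(=O)O)N2C(=O)[C@H]([C@H](O)CCc3ccccc3)[C@H]2O1` gives 21 h. The steps seen so far are a 1.2-fold higher number from compound 1 to compound 2 (0.09 log units; within the scatter), a 4.2-fold higher number from compound 1 to compound 3 (0.62 log units; beyond the scatter) and a 3.4-fold higher number from compound 2 to compound 3 (0.53 log units; beyond the scatter); each of them swaps a group on the saturated chain carbon, so none bears directly on a change of configuration. Compound 4 `CC(C)(C)C1=C(C(=O)O)N2C(=O)[C@H](CO)[C@@H]2O1` differs from compound 1 in that (the two compounds have the same atoms and bonds and differ only in configuration as drawn: 1 of 2 stereo elements differ; a stereocentre at a saturated ring carbon is drawn R in compound 1 and S in compound 4). Within the data shown here, with no measured step of this kind, the value expected for compound 4 in this assay is 5 h, with a range from 2.5 h to 10 h. For compound 4 this estimate means no change at the digits printed from compound 1 to compound 4 (within the scatter), a step expected to stay within the scatter.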

Compound 4, half-life: 2.4 h
Estimate against measurement, compound 4: 2.1-fold (0.32 log units) above; measured number outside the range, below it.
By their numbers in this assay, from the lowest: compound 4; then compounds 1 and 2 (each within the scatter of the next); then compound 3.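

Compounds 1 to 3 vary only the group on the chain carbon, whereas this pair changes only the configuration at a saturated ring carbon, and in this assay that gives a 2.1-fold lower number from compound 1 to compound 4 (0.32 log units; beyond the scatter). Configuration at this ring carbon therefore affects how long the compound lasts, even with no group changed. The step can be tied to this single stereocentre: the fact that compounds 1 and 4 differ only in the configuration as drawn.

On these data alone, whether the same change acts alike with the methoxycarbonyl of compound 2 or the phenethyl of compound 3 remains open. So does how an amine on the chain carbon would behave in either configuration.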